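The compounds below may be only part of what the source reports. "The series", "measured", "known", "first", "only" and "open" are said of these compounds alone.

In a functional assay on MCF7 cells (Homo sapiens) for antiproliferative activity, read by MTT assay, with a stated time of 48 h (on this read-out higher numbers stand for weaker inhibition and lower numbers for stronger inhibition), compound 1 `CCNCC(=O)Nc1cc(OC)ccc1C(=O)c1cc(OC)c(OC)c(OC)c1` gives 1050 nM and compound 2 `COc1ccc(C(=O)c2cc(OC)c(OC)c(OC)c2)c(NC(=O)CN(C)C)c1` gives 790 nM. The change between them, (dimethylamino in place of ethylamino on a saturated chain carbon bound to a carbonyl carbon), produced a 1.3-fold lower number from compound 1 to compound 2 (0.12 log units; within the scatter). Compound 3 `C=C(c1cc(OC)c(OC)c(OC)c1)c1ccc(OC)cc1NC(=O)CNCC` carries a different core; the difference between the two cores is not broken down here. In this assay compound 3 gives 860 nM, a number within the scatter of both compound 1 and compound 2. Compound 4 `C=C(c1cc(OC)c(OC)c(OC)c1)c1ccc(OC)cc1NC(=O)CN(C)C` is not yet measured. It differs from compound 3 by dimethylamino in place of ethylamino on a saturated chain carbon bound to a carbonyl carbon, the same change at the same place as between compound 1 and compound 2. The earlier step of a 1.3-fold lower number from compound 1 to compound 2 (0.12 log units; within the scatter) stayed within the scatter, and that single pair is the only basis available. For compound 4 a step of similar size is expected, a 1.2-fold lower number from compound 3 to compound 4 (0.09 log units; within the scatter). The estimate for compound 4 in this assay is 700 nM, expected to lie between 350 nM and 1400 nM.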

Compound 4, half-maximal inhibitory concentration: 390 nM
Compound 4: middle estimate off by 1.8-fold (0.25 log units), on the high side; low and high end bracket the measured number.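

In this assay, dimethylamino in place of ethylamino on the core of compound 3 gives a 2.2-fold lower number from compound 3 to compound 4 (0.34 log units; beyond the scatter), a modest step beyond the scatter. Set beside the step on the other core, the two do not differ beyond what repeated measurement allows: the same change on two cores in this assay, a 1.3-fold lower number (0.12 log units; within the scatter) from compound 1 to compound 2 and a 2.2-fold lower number (0.34 log units; beyond the scatter) from compound 3 to compound 4, 1.7-fold (0.22 log units) apart, within the scatter of two such steps. This gives no ground to treat the change as behaving differently on the two cores, but with one pair per core it does not show that the step is larger on the core of compound 3, or that it would carry to any further core.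

The compounds shown leave open how diethylamino, an unsubstituted amino group or a longer chain carrying the amine would read in this assay on either core.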